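Swapping a Hydroxy for an Amino on a Glyoxylamide Chain

The source may hold more compounds than are shown below. What is called first, only, known or untested is meant among the compounds shown, and "the series" means these compounds.

Three small oxime-bearing amides have been tested in an ADME assay for permeability, using PAMPA; on this read-out higher numbers stand for higher permeability and lower numbers for lower permeability. Compound 1, `O=C(/C=N/O)NCC(O)CO`, carries a short chain ending in two hydroxy groups and gives 0.61 10^-6 cm/s. Compound 2, `O=C(/C=N/O)NCCN1CCCC1`, carries a pyrrolidine instead and gives 1.1 10^-6 cm/s, a number that lies within the usual scatter of the number for compound 1. Compound 3, `C[N+](C)(C)CCNC(=O)/C=N/O`, carries a trimethylammonium group and gives 1.6 10^-6 cm/s, which stands beyond the scatter above compound 1. Compound 1 thus sits at the low end of this small set, though only compound 3 is clearly separated from it.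

The next compound, compound 4, `NCC(O)CNC(=O)/C=N/O`, has not yet been measured. Its difference from compound 1 is amino in place of hydroxy on a saturated chain carbon, two bonds along the chain from an oxygen on a saturated carbon. Of the three measured compounds, the two that carry a nitrogen on the chain, compound 2 with 1.1 10^-6 cm/s and compound 3 with 1.6 10^-6 cm/s, give numbers at or above that of compound 1, so a drop is not expected. Among the compounds with values here, still, no measured pair shows this exact exchange, and the safest expectation is a step from compound 1 to compound 4 of a 1.2-fold higher number from compound 1 to compound 4 (0.09 log units; within the scatter), not beyond the scatter. Compound 4 is therefore estimated at 0.75 10^-6 cm/s, with a likely range from 0.3 10^-6 cm/s to 1.8 10^-6 cm/s in this assay.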

Compound 4, apparent permeability: 0.81 10^-6 cm/s
Compound 4: middle estimate off by 1.1-fold (0.03 log units), on the low side, and the stated range covers the measured number.
By their numbers in this assay, from the lowest: compounds 1, 4, 2 and 3 (each within the scatter of the next, the first and the last beyond it).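

Within the data shown here, this is the only pair in the set that differs in one place, so the hydroxymethyl to aminomethyl exchange can now be read directly: in this assay it gives a 1.3-fold higher number from compound 1 to compound 4 (0.12 log units; within the scatter) and stays inside the usual spread of repeated measurements. On a saturated chain carbon, two bonds along the chain from an oxygen on a saturated carbon, hydroxy and amino therefore cannot be told apart on this read-out, even though one heavy atom changes from oxygen to nitrogen while each group counts one hydrogen-bond donor and one hydrogen-bond acceptor. No measurement at hand speaks to why the two groups read alike, so the result stands as an observation only.

As far as these compounds go, what a carboxylic acid or a dimethylamino group would give at this same place remains open, as does whether a longer chain carrying the amino group would read like compound 4. Compound 2 and compound 3 differ from compound 1 in more than one place, so they cannot settle how a nitrogen at this position behaves beyond this single exchange.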